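The compounds below may be only part of what the source reports. "The series", "measured", "known", "first", "only" and "open" are said of these compounds alone.

Measured so far:
Compound 1, `Cc1cc(C(=O)Nc2ccc(F)cn2)ccc1N(CCN1CCCC1)C(=O)Nc1ccc(Cl)cc1`: 0.458 h
Compound 2, `Cc1cc(C(=O)Nc2ccc(Cl)cc2)ccc1N(CC(=O)N1CCOCC1)C(=O)Nc1ccc(Cl)cc1`: 0.532 h

In an ADME assay on microsomes from liver (Homo sapiens) for metabolic stability (on this read-out higher numbers stand for a longer-lived compound and lower numbers for a shorter-lived compound), compound 2 gives 0.532 h, and compound 1 gives 0.458 h; the two numbers lie within the scatter of each other, so no order between them can be read from this assay. Compound 3, `Cc1cc(C(=O)Nc2ccc(Cl)cc2)ccc1N(CCN1CCOCC1=O)C(=O)Nc1ccc(Cl)cc1`, has not yet been measured. It keeps every atom of compound 2 but joins them differently: (3-oxomorpholin-4-yl)methyl in place of (morpholin-4-yl)carbonyl on a saturated chain carbon bound to an amide-type nitrogen. Among the measured compounds shown here, no pair of measured compounds shows a step of this kind, so nothing in the data tells how much this assay responds to such a rearrangement. With the same atoms present and the shared core untouched, the step from compound 2 to compound 3 is expected to be a 1.1-fold lower number from compound 2 to compound 3 (0.03 log units; within the scatter), that is, nothing beyond the scatter in either direction. Compound 3 is therefore estimated at 0.5 h, with a range from 0.25 h to 1 h.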

Compound 3, half-life: 0.152 h
The estimate for compound 3 lay 3.3-fold (0.52 log units) above the measured number, and the stated range ends above it.
By their numbers in this assay, from the lowest: compound 3; then compounds 1 and 2 (each within the scatter of the next).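

In this assay, the place on a saturated chain carbon bound to an amide-type nitrogen proves sensitive to how the same atoms are joined: (3-oxomorpholin-4-yl)methyl in place of (morpholin-4-yl)carbonyl gives a 3.5-fold lower number from compound 2 to compound 3 (0.54 log units; beyond the scatter). Neither group differs from the other in the counts of atoms, rings, donors or acceptors, so this read-out follows something that those counts do not capture, which compound 1 and compound 2, differing in more than one place, could not reveal. Nothing at hand explains the size or direction of this step.

Going by these compounds, it remains open whether a plain 2-(morpholin-4-yl)ethyl group, with no carbonyl, would fall nearer compound 2 or compound 3. On these data alone, it is also open whether the same rearrangement would have a similar effect with the other parts of the compound changed.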